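From 4-fluorophenyl to 3-nitrophenyl on a shared core

The compounds below may be only part of what the source reports. "The series", "measured", "known", "first", "only" and "open" are said of these compounds alone.

Compound 1 `CC(=O)O[C@H]1CC[C@]2(C)[C@H](CC[C@@](C)(O)[C@H]2CC[C@@H]2C(C)=CC[C@H]3[C@H](CC[C@]3(C)O)C2(C)C)OC1(C)C`, compound 2 `CC1=CC[C@H]2[C@H](CC[C@]2(C)O)C(C)(C)[C@@H]1CC[C@H]1[C@]2(C)CC[C@H](OC(=O)c3ccncc3)C(C)(C)O[C@H]2CC[C@@]1(C)O` and compound 3 `CC1=CC[C@H]2[C@H](CC[C@]2(C)O)C(C)(C)[C@@H]1CC[C@H]1[C@]2(C)CC[C@H](OC(=O)c3ccc(F)cc3)C(C)(C)O[C@H]2CC[C@@]1(C)O` share one core and differ only in the group on a carbonyl carbon. In a functional assay on MCF7 cells (Homo sapiens) for antiproliferative activity, read by MTT assay, with a stated time of 72 h (a higher number here means a weaker inhibitor, a lower number a stronger inhibitor), compound 1 gives 47900 nM, compound 2 gives 25300 nM and compound 3 gives 33500 nM. Compound 3 therefore stands with the other two, inside the scatter of both, and the three numbers cannot be ranked with confidence. The steps show this directly: a 1.9-fold lower number from compound 1 to compound 2 (0.28 log units; within the scatter), a 1.4-fold lower number from compound 1 to compound 3 (0.16 log units; within the scatter) and a 1.3-fold higher number from compound 2 to compound 3 (0.12 log units; within the scatter). Compound 4 `CC1=CC[C@H]2[C@H](CC[C@]2(C)O)C(C)(C)[C@@H]1CC[C@H]1[C@]2(C)CC[C@H](OC(=O)c3cccc([N+](=O)[O-])c3)C(C)(C)O[C@H]2CC[C@@]1(C)O` brings a new change, 3-nitrophenyl in place of 4-fluorophenyl on a carbonyl carbon. Among the measured compounds shown here, no measured compound carries the 3-nitrophenyl group, so only the earlier swaps at this carbon offer guidance, and each of them stayed small. A shift beyond the scatter is therefore not expected, and the expected change is a 1.1-fold lower number from compound 3 to compound 4 (0.05 log units; within the scatter). For compound 4 the estimated value is 30000 nM, with an expected range from 14000 nM to 60000 nM.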

Compound 4, half-maximal inhibitory concentration: 36000 nM
Compound 4: the middle estimate sits 1.2-fold (0.08 log units) below what was measured; measured number inside the range.
By their numbers in this assay, from the lowest: compounds 2, 3, 4 and 1 (each within the scatter of the next).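

In this assay the 3-nitrophenyl group carries hydrogen-bond acceptors that 4-fluorophenyl lacks, yet a 1.1-fold higher number from compound 3 to compound 4 (0.03 log units; within the scatter) leaves the two numbers within the scatter of each other. The comparisons with the other two groups read the same way, with a 1.4-fold higher number from compound 2 to compound 4 (0.15 log units; within the scatter) and a 1.3-fold lower number from compound 1 to compound 4 (0.12 log units; within the scatter) also within the scatter, so methyl, pyridin-4-yl, 4-fluorophenyl and 3-nitrophenyl cannot be told apart on this carbonyl carbon. Nothing else is available here that bears on this result.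

The compounds shown leave open whether any other group on this carbonyl carbon, such as an amine, a carboxylic acid or a longer chain, would move the number beyond the scatter. As far as these compounds go, all of them also keep the ester link, so what an amide in its place would do remains open.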